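Repeating a Methoxy Addition on a Carbon-Only Ring

This account rests on a few compounds, and the source may have more. Where it says the series, first, only, none or still open, it means among the compounds named here.

Of the compounds shown here, three have so far been measured in an assay on isolated protein for inhibition of N-acylethanolamine-hydrolyzing acid amidase (Homo sapiens), read by fluorescence, with a stated time of 90 min; on this read-out lower numbers stand for stronger inhibition and higher numbers for weaker inhibition. Compound 2 `N#CN1CC(OCc2ccc(-c3cccnc3)cc2)C1` gives 12 nM. Compound 1 `COc1ccncc1-c1ccc(COC2CN(C#N)C2)cc1` gives 40 nM; the change between them, (methoxy in place of hydrogen on an aromatic carbon), produced a 3.3-fold higher number from compound 2 to compound 1 (0.52 log units; beyond the scatter). Compound 3 `N#CN1CC(OCc2ccc(Oc3ccccc3)cc2-c2ccccc2)C1` gives 8.5 nM, the lowest of the three numbers, although its gap to compound 2 lies within the scatter. The difference between the cores of compound 2 and compound 3 is not broken down here.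

Compound 4 `COc1ccccc1-c1cc(Oc2ccccc2)ccc1COC1CN(C#N)C1` has not yet been measured. It differs from compound 3 by methoxy in place of hydrogen on an aromatic carbon, the same kind of change as that from compound 2 to compound 1, but the surroundings differ: in compound 1 the methoxy sits on a six-membered aromatic ring with one nitrogen, opposite the ring nitrogen, whereas in compound 4 it sits on a six-membered aromatic ring of carbon only, in both cases ortho to a large group. For compound 4 the expected step is a 2.1-fold higher number from compound 3 to compound 4 (0.33 log units; beyond the scatter), resting on the earlier step that gave a 3.3-fold higher number from compound 2 to compound 1 (0.52 log units; beyond the scatter), with the different ring leaving the size uncertain. In this assay compound 4 is estimated at 18 nM, expected to fall between 6 nM and 55 nM.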

Compound 4, half-maximal inhibitory concentration: 23.7 nM
The estimate for compound 4 lay 1.3-fold (0.12 log units) below the measured number; measured number inside the range.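

In this assay, methoxy in place of hydrogen on an aromatic carbon again gave weaker inhibition, with a 2.8-fold higher number from compound 3 to compound 4 (0.45 log units; beyond the scatter). Set beside the earlier case, the change carried over from one core to the other in direction and, within the scatter, in size: the same change on two cores in this assay, a 3.3-fold higher number (0.52 log units; beyond the scatter) from compound 2 to compound 1 and a 2.8-fold higher number (0.45 log units; beyond the scatter) from compound 3 to compound 4, 1.2-fold (0.08 log units) apart, within the scatter of two such steps. Among these compounds, this agreement rests on only two pairs, the core of compound 2 and the core of compound 3, with the methoxy on a ring with one nitrogen in the first and on a carbon-only ring in the second, so it shows that the step held on these two cores but gives no general rule for the series and does not explain why the number rises.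

The compounds shown leave open whether a different group in the place of methoxy, such as ethoxy, a fluorine atom or a hydroxyl group, would give a similar step. On these data alone, it also remains open whether the methoxy step would hold on any third core.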